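The source may report more compounds than this note shows. Statements on the series, on what has been measured and on what is new or still open speak of the compounds shown alone.

Measured in a functional assay on A2780 cells (Homo sapiens) for antiproliferative activity, read by fluorescence, with a stated time of 72 h; on this read-out lower numbers stand for stronger inhibition and higher numbers for weaker inhibition:
compound 1 `CN1CCC(C(=O)N2Cc3c(NC(=O)c4ccc5ccccc5c4)n[nH]c3C2(C)C)CC1`: 270 nM
compound 2 `CN1CCC(C(=O)N2Cc3c(NC(=O)c4ccc(Cl)cc4)n[nH]c3C2(C)C)CC1`: 120 nM
compound 3 `CN1CCC(C(=O)N2Cc3c(NC(=O)Nc4cccc(F)c4)n[nH]c3C2(C)C)CC1`: 350 nM
Not yet measured: compound 4 `CN1CCC(C(=O)N2Cc3c(NC(=O)c4ccccc4)n[nH]c3C2(C)C)CC1`

Compound 3 does not separate from the naphthalen-2-yl analogue (a 1.3-fold higher number from compound 1 to compound 3 (0.11 log units; within the scatter)). Its number does lie clear of the 4-chlorophenyl analogue (a 2.9-fold higher number from compound 2 to compound 3 (0.46 log units; beyond the scatter)).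

The next change gives compound 4, with phenyl in place of (3-fluorophenyl)amino on a carbonyl carbon. Cut one bond further out, this reads (3-fluorophenyl)carbamoyl to benzoyl.

All three measured steps are changes at this same carbonyl, and all are small to modest. The two compounds with a carbon ring directly on the carbonyl differ modestly from each other (a 2.3-fold lower number from compound 1 to compound 2 (0.35 log units; beyond the scatter)). Going from either of them to compound 3 gives mixed results, so leaving out the amino link has no single measured size. Going by the values given here, no measured compound isolates the bare phenyl, so the evidence is indirect. Compound 4 should fall within the range already seen, between compound 2 (120 nM) and compound 3 (350 nM).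

A small move toward a lower number is expected (a 1.6-fold lower number from compound 3 to compound 4 (0.20 log units; within the scatter)). For compound 4 the estimated value is 220 nM, with an expected range of 90 nM to 550 nM.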

Compound 4, half-maximal inhibitory concentration: 160 nM
The estimate for compound 4 lay 1.4-fold (0.14 log units) above the measured number, within the range that was stated.
By their numbers in this assay, from the lowest: compounds 2, 4, 1 and 3 (each within the scatter of the next, the first and the last beyond it).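

In this assay, the change from (3-fluorophenyl)carbamoyl to benzoyl gives the first direct measure of losing the amino link together with the fluoro substituent at this carbonyl carbon, a 2.2-fold lower number from compound 3 to compound 4 (0.34 log units; beyond the scatter), and the step lies beyond the scatter. The bare phenyl does not separate from either of the other carbon rings: hydrogen in place of chloro on an aromatic carbon gives a 1.3-fold higher number from compound 2 to compound 4 (0.12 log units; within the scatter), and phenyl in place of naphthalen-2-yl gives a 1.7-fold lower number from compound 1 to compound 4 (0.23 log units; within the scatter), even though those two analogues separate modestly from each other (a 2.3-fold lower number from compound 1 to compound 2 (0.35 log units; beyond the scatter)). The data shown offer no measurement that explains any of these steps.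

A phenylamino group without the fluoro would be needed to separate the share of the fluoro from that of the amino link in the step to benzoyl. Also open, on these data alone, is how a non-aromatic cyclohexyl or a pyridin-3-yl ring on the same carbonyl carbon would read against the phenyl.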